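From Formyl to a Sulfur-Bearing Side Chain

The source may hold more compounds than are shown below. What is called first, only, known or untested is meant among the compounds shown, and "the series" means these compounds.

For the measured compounds named here, in a functional assay on P388 cells (Mus musculus) for cytotoxicity (a lower number here means a stronger inhibitor, a higher number a weaker inhibitor), compound 2 `COc1ccc(C[C@H]2C(=O)N[C@@H](C)C(=O)N(C)[C@H]3Cc4ccc(cc4)Oc4cc(ccc4OC)C[C@@H](C(=O)N[C@H](C)C(=O)N[C@@H](CC=O)C(=O)N2C)N(C)C3=O)cc1` gives 33.9 nM and holds the lowest of the three numbers so far. Compound 3 `COc1ccc(C[C@H]2C(=O)N[C@@H](C)C(=O)N(C)[C@H]3Cc4ccc(cc4)Oc4cc(ccc4OC)C[C@@H](C(=O)N[C@H](C)C(=O)N[C@@H](CCCCO)C(=O)N2C)N(C)C3=O)cc1` gives 219 nM and compound 1 `COc1ccc(C[C@H]2C(=O)N[C@@H](C)C(=O)N(C)[C@H]3Cc4ccc(cc4)Oc4cc(ccc4OC)C[C@@H](C(=O)N[C@H](C)C(=O)NC4(SCCS4)C(=O)N2C)N(C)C3=O)cc1` gives 631 nM on the same read-out. Compound 4 `COc1ccc(C[C@H]2C(=O)N[C@@H](C)C(=O)N(C)[C@H]3Cc4ccc(cc4)Oc4cc(ccc4OC)C[C@@H](C(=O)N[C@H](C)C(=O)N[C@@H](CCSC)C(=O)N2C)N(C)C3=O)cc1` has (methylsulfanyl)methyl in place of formyl on a saturated chain carbon bound to a saturated ring carbon and is otherwise unchanged. Going by the values given here, the one measured step at this place, 3-hydroxypropyl in place of formyl, is a 6.5-fold higher number from compound 2 to compound 3 (0.81 log units; beyond the scatter) and it also removes the formyl, so a rise of similar or smaller size is expected in this assay here. The estimated step is a 2.9-fold higher number from compound 2 to compound 4 (0.47 log units; beyond the scatter) on this single comparison. For compound 4 the estimated value is 100 nM with 35 nM to 300 nM as its expected range.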

Compound 4, half-maximal inhibitory concentration: 20.4 nM
Estimate against measurement, compound 4: 4.9-fold (0.69 log units) above, and the stated range ends above it.
By their numbers in this assay, from the lowest: compounds 4 and 2 (each within the scatter of the next); then compound 3; then compound 1.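

In this assay, the formyl on this side chain is not needed to keep the number low, since replacing it with (methylsulfanyl)methyl stays within the scatter (a 1.7-fold lower number from compound 2 to compound 4 (0.22 log units; within the scatter)). Compound 3 and compound 4 both lack the formyl yet stand far apart (an 11-fold lower number from compound 3 to compound 4 (1.03 log units; beyond the scatter)), so losing it does not by itself raise the number; what takes its place matters. No supporting measurement explains why these side chains differ.

On these data alone, it remains open how an amine or a carboxylic acid at this position would compare with the methylsulfanyl end of compound 4.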